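The source may report more compounds than this note shows. Statements on the series, on what has been measured and on what is new or still open speak of the compounds shown alone.

Compound 2 `COc1ccc(N(Cc2ccc(F)cc2)NC(=O)NCCCN2CCN(c3ccccc3OC)CC2)cc1` gives 2.9 nM in an assay on CHO cells for displacement of a labelled ligand from D(4) dopamine receptor (Homo sapiens), read by radioligand binding (a higher number here means a weaker inhibitor, a lower number a stronger inhibitor), and so holds the highest of the two numbers in hand; its nearest neighbour is compound 1 `COc1ccc(N(Cc2ccccc2)NC(=O)NCCCN2CCN(c3ccccc3OC)CC2)cc1`, which gives 1.7 nM, the two being separated by a 1.7-fold higher number from compound 1 to compound 2 (0.23 log units; within the scatter). Compound 3 `COc1ccc(N(Cc2cccc(OC)c2)NC(=O)NCCCN2CCN(c3ccccc3OC)CC2)cc1` differs from compound 2 by 3-methoxyphenyl in place of 4-fluorophenyl on a saturated chain carbon bound to a nitrogen on an aromatic ring. Going by the values given here, the only measured step touches this same ring, where fluoro replaced hydrogen, and it stayed within the scatter. No measured pair exchanges a fluoro for a methoxy group, so the present change has no direct precedent among these compounds. Because a 1.7-fold higher number from compound 1 to compound 2 (0.23 log units; within the scatter) did not carry the number beyond the scatter, the step to compound 3 in this assay is expected to be a 1.2-fold lower number from compound 2 to compound 3 (0.06 log units; within the scatter). The estimate for compound 3 in this assay is therefore 2.5 nM, with a range from 0.8 nM to 8 nM.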

Compound 3, inhibition constant: 33 nM
Compound 3: middle estimate off by 13-fold (1.12 log units), on the low side; measured number outside the range, above it.
By their numbers in this assay, from the lowest: compounds 1 and 2 (each within the scatter of the next); then compound 3.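

In this assay, the ring on this saturated chain carbon proves not to be indifferent to what it carries: the step of an 11-fold higher number from compound 2 to compound 3 (1.06 log units; beyond the scatter) is large, and so is that of a 19-fold higher number from compound 1 to compound 3 (1.29 log units; beyond the scatter), with methoxy in place of hydrogen. Fluoro in place of hydrogen on the same ring gave only a 1.7-fold higher number from compound 1 to compound 2 (0.23 log units; within the scatter), so among these three compounds the outcome depends on the group introduced and the ring's earlier flat reading does not extend to 3-methoxyphenyl. Nothing available accounts for this large step.

The 4-fluorophenyl and 3-methoxyphenyl groups differ in both the substituent and its place on the ring, and these compounds do not separate the two. As far as these compounds go, how hydroxy, chloro or an amine on this ring would read in this assay also remains open.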